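A few compounds are considered here, and "the series" means these few. Any claim that something is new, unique, unknown or untested is made for them only; others in the source may bear on it.

Series notes, agonist read-out in a functional assay on HEK293 cells for agonist activity at Glucose-dependent insulinotropic receptor (Homo sapiens), read by a luciferase reporter; on this read-out lower numbers stand for an effect already at smaller amounts and higher numbers for an effect only at larger amounts of compound. Of the compounds shown here, two have been measured so far. Compound 1 `CC#CCn1c(N2CCC[C@@H](N)C2)nc2c1c(=O)n(CCCN1CCN(c3nc(-c4ccccc4)cs3)CC1)c(=O)n2C` carries 4-phenyl-1,3-thiazol-2-yl on the ring amine nitrogen and in this assay compound 1 gives 650 nM. Compound 2 `CC#CCn1c(N2CCC[C@@H](N)C2)nc2c1c(=O)n(CCCN1CCN(c3noc(-c4ccccc4)n3)CC1)c(=O)n2C` replaces that group by 5-phenyl-1,2,4-oxadiazol-3-yl; in this assay compound 2 gives 1450 nM. Among the measured compounds shown here, the single step available, a 2.2-fold higher number from compound 1 to compound 2 (0.35 log units; beyond the scatter), shows that swapping one five-membered aromatic group bearing a phenyl for another at this position costs a modest amount. Compound 2 therefore stands as the higher of the two numbers, set apart from compound 1 by more than the scatter.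

Compound 3 `CC#CCn1c(N2CCC[C@@H](N)C2)nc2c1c(=O)n(CCCN1CCN(c3ncc(OC)cn3)CC1)c(=O)n2C` is not yet measured. Its change from compound 2 is 5-methoxypyrimidin-2-yl in place of 5-phenyl-1,2,4-oxadiazol-3-yl on an amine nitrogen in a ring. For the measured compounds named here, no measured step covers a move from a five-membered to a six-membered aromatic group here, nor the loss of the phenyl; the only step on this position, from thiazolyl to oxadiazolyl, is of limited relevance and was modest. With that, a step of roughly a 1.1-fold higher number from compound 2 to compound 3 (0.04 log units; within the scatter) is expected, most likely within or near the scatter in either direction. For compound 3 the estimate in this assay is 1600 nM, with a range from 550 nM to 4800 nM.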

Compound 3, half-maximal effective concentration: 2260 nM
Compound 3: middle estimate off by 1.4-fold (0.15 log units), on the low side; measured number inside the range.
By their numbers in this assay, from the lowest: compound 1; then compounds 2 and 3 (each within the scatter of the next).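

In this assay, 5-methoxypyrimidin-2-yl, the first six-membered aromatic group seen on this ring amine nitrogen and one with no phenyl ring, cannot be told apart from 5-phenyl-1,2,4-oxadiazol-3-yl (a 1.6-fold higher number from compound 2 to compound 3 (0.19 log units; within the scatter)). Against 4-phenyl-1,3-thiazol-2-yl the same group lies beyond the scatter (a 3.5-fold higher number from compound 1 to compound 3 (0.54 log units; beyond the scatter)), so compound 1 now stands apart from both other compounds, and a phenyl ring on the group is no sufficient condition for the lowest number, since compound 2 carries one and still falls with compound 3. No measurement at hand offers an explanation for these numbers.

As far as these compounds go, it remains open whether the lower number of compound 1 belongs to the thiazole ring itself or to the way its phenyl ring is placed, a question that a thiazol-2-yl without phenyl or a 5-phenyl-1,3-thiazol-2-yl would address. The share of the methoxy group in compound 3 is also unresolved, as is the effect of an amine or a carboxylic acid on the phenyl ring of compound 1, or of a longer chain to the ring that bears these groups.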